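From dimethylamino to nitro: expectations for compound 4

The source may hold more compounds than are shown below. What is called first, only, known or untested is meant among the compounds shown, and "the series" means these compounds.

In a functional assay on HT-29 cells (Homo sapiens) for cytotoxicity, read by sulforhodamine B assay (a lower number here means that less compound is tolerated, a higher number that more compound is tolerated), compound 1 (`CC1=CC[C@@H]([C@@](C)(O)CCCC(C)(C)NC(=S)N/N=C\c2ccccc2)CC1`) gives 57400 nM. Compound 2 (`CC1=CC[C@@H]([C@@](C)(O)CCCC(C)(C)NC(=S)N/N=C\c2ccc(C)cc2)CC1`) gives > 100000 nM, which is a limit and not a number. Compound 3 (`CC1=CC[C@@H]([C@@](C)(O)CCCC(C)(C)NC(=S)N/N=C\c2ccc(N(C)C)cc2)CC1`) gives > 100000 nM, also a limit, and so stands at the limit of > 100000 nM in this assay, at which 2 of the 3 values shown sit.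

Compound 4 (`CC1=CC[C@@H]([C@@](C)(O)CCCC(C)(C)NC(=S)N/N=C\c2ccc([N+](=O)[O-])cc2)CC1`) has nitro in place of dimethylamino on an aromatic carbon, para to a large group: nitro in place of dimethylamino on an aromatic carbon.

The relevant measured steps are an at least 1.7-fold higher number from compound 1 to compound 2 (0.24 log units; that floor lies within the scatter) and an at least 1.7-fold higher number from compound 1 to compound 3 (0.24 log units; that floor lies within the scatter), while a step that the two limits leave unreadable from compound 2 to compound 3 gives no size. With only these floors to go on, at most a modest move is expected, towards compound 1 at 57400 nM. The expected step is an at least 1.4-fold lower number from compound 3 to compound 4 (0.15 log units; that floor lies within the scatter). For compound 4 the estimate is 70000 nM, with an expected range from 25000 nM to 100000 nM.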

Compound 4, concentration lethal to 50% of the cells: > 100000 nM
Compound 4: only a limit was reported (the forecaster's own chance of this, stated with the estimate: 40%); at least 1.4-fold (0.15 log units) between middle value and limit.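

In this assay, the reading for nitro on an aromatic carbon, para to a large group, is a limit and not a number: the limit of > 100000 nM in this assay, at which 3 of the 4 values shown sit.

Among these compounds, the only readable new step is an at least 1.7-fold higher number from compound 1 to compound 4 (0.24 log units; that floor lies within the scatter). Among the compounds shown here, the steps among compound 2, compound 3 and compound 4 cannot be read, so methyl, dimethylamino and nitro cannot be ranked, and compound 1, without a substituent at this place, remains the only compound with a number.

As far as these compounds go, what a carboxylic acid or a primary amine at this place would give stays open, as does the true size of every step ending at a limit.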